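Benzofuranoyl pyrazolines: predicting a dimethoxyphenyl analogue

The compounds below may be only part of what the source reports. "The series", "measured", "known", "first", "only" and "open" are said of these compounds alone.

Measured compounds:
compound 1 `COc1ccc(C2CC(c3ccccc3)=NN2C(=O)c2cc3ccccc3o2)cc1OC` 6.89 ug/mL
compound 2 `O=C(c1cc2ccccc2o1)N1N=C(c2ccccc2)CC1c1ccccc1Cl` 6.22 ug/mL
compound 3 `O=C(c1cc2ccccc2o1)N1N=C(c2ccc(Cl)cc2)CC1c1ccccc1Cl` 44.8 ug/mL

Three compounds sharing a benzofuranoyl pyrazoline core were tested in a functional assay on A2780 cells (Homo sapiens) for antiproliferative activity, read by MTT assay, with a stated time of 72 h; a higher number here means a weaker inhibitor, a lower number a stronger inhibitor. Compound 2 gives 6.22 ug/mL and compound 1 gives 6.89 ug/mL. The change from compound 2 to compound 1 is 3,4-dimethoxyphenyl in place of 2-chlorophenyl on a saturated ring carbon, and the step is a 1.1-fold higher number from compound 2 to compound 1 (0.04 log units; within the scatter). Compound 3 gives 44.8 ug/mL; it differs from compound 2 by chloro in place of hydrogen on an aromatic carbon, and that step is a 7.2-fold higher number from compound 2 to compound 3 (0.86 log units; beyond the scatter).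

Compound 4 `COc1ccc(C2CC(c3ccc(Cl)cc3)=NN2C(=O)c2cc3ccccc3o2)cc1OC` has not yet been measured. It differs from compound 3 by 3,4-dimethoxyphenyl in place of 2-chlorophenyl on a saturated ring carbon. This is the same kind of change as from compound 2 to compound 1, though the surroundings differ: in the earlier pair the ring atom two ring bonds away bears a phenyl group (6 heavy atoms), whereas here it bears a 4-chlorophenyl group (7 heavy atoms).

Because the earlier step of a 1.1-fold higher number from compound 2 to compound 1 (0.04 log units; within the scatter) lay within the scatter, compound 4 is expected to sit close to compound 3, with an estimated step of a 1.1-fold higher number from compound 3 to compound 4 (0.03 log units; within the scatter). Compound 4 is therefore estimated at 48 ug/mL in this assay, between 20 ug/mL and 110 ug/mL.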

Compound 4, half-maximal inhibitory concentration: 6.29 ug/mL
The estimate for compound 4 lay 7.6-fold (0.88 log units) above the measured number; measured number below the stated range.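

In this assay, 3,4-dimethoxyphenyl in place of 2-chlorophenyl gives a 7.1-fold lower number from compound 3 to compound 4 (0.85 log units; beyond the scatter), so a change that did almost nothing on the earlier core does not carry over unchanged to this one: the same change on two cores in this assay, a 1.1-fold higher number (0.04 log units; within the scatter) from compound 2 to compound 1 and a 7.1-fold lower number (0.85 log units; beyond the scatter) from compound 3 to compound 4, 7.9-fold (0.90 log units) apart, beyond the scatter of two such steps Chloro in place of hydrogen on an aromatic carbon shows the same dependence, with a 1.1-fold lower number from compound 1 to compound 4 (0.04 log units; within the scatter) when the saturated ring carbon bears 3,4-dimethoxyphenyl: the same change on two cores in this assay, a 7.2-fold higher number (0.86 log units; beyond the scatter) from compound 2 to compound 3 and a 1.1-fold lower number (0.04 log units; within the scatter) from compound 1 to compound 4, 7.9-fold (0.90 log units) apart, beyond the scatter of two such steps These four compounds show that neither change has a fixed size here and that the outlying number belongs to compound 3 alone, but they do not show why, and this single set gives no rule for other cores.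

From the compounds shown here alone, it remains open whether the high number of compound 3 is specific to 2-chlorophenyl together with 4-chlorophenyl. A bromo or dimethylamino group in place of the chloro of the 4-chlorophenyl group could show whether the same dependence holds beyond these two groups.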